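Methyl added to a dichlorophenyl sulfonamide: cytotoxicity outlook

A few compounds are considered here, and "the series" means these few. Any claim that something is new, unique, unknown or untested is made for them only; others in the source may bear on it.

Compound 1 `CCc1ccc(S(=O)(=O)N2CCC(N3CCC(C)CC3)CC2)cc1`: > 5000 nM
Compound 2 `CC1CCN(C2CCN(S(=O)(=O)c3cnc(Cl)s3)CC2)CC1`: > 10000 nM
Compound 3 `CC1CCN(C2CCN(S(=O)(=O)c3ccc(Cl)cc3Cl)CC2)CC1`: > 5000 nM

Three compounds share one core and differ only in the aryl group on the sulfonyl sulfur. In an ADME assay on HCT-116 cells (Homo sapiens) for cytotoxicity, read by CellTiter-Glo, with a stated time of 72 h (on this read-out higher numbers stand for weaker inhibition and lower numbers for stronger inhibition), compound 1 gives > 5000 nM, which is a limit of the assay and not a number. In this assay compound 2 gives > 10000 nM, again a limit. In this assay compound 3 gives > 5000 nM, also a limit; two of the three values sit at the limit of > 5000 nM in this assay, at which 2 of the 3 values shown sit, and one at the limit of > 10000 nM in this assay, at which 1 of the 3 values shown sits. Every value is a limit. The steps a step that the two limits leave unreadable from compound 1 to compound 2, a step that the two limits leave unreadable from compound 1 to compound 3 and a step that the two limits leave unreadable from compound 2 to compound 3 cannot be read in size, and compound 3 cannot be ranked against the others.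

Compound 4 `Cc1cc(Cl)cc(Cl)c1S(=O)(=O)N1CCC(N2CCC(C)CC2)CC1` differs from compound 3 by methyl in place of hydrogen on an aromatic carbon. Within the data shown here, none of the measured steps is readable, so no step size can be borrowed for this change. Compound 4 is therefore expected to remain a limit in this assay, with an estimate of 10000 nM (3000 nM to 50000 nM). The expected step that the limit leaves unreadable from compound 3 to compound 4 is estimated as none beyond the scatter.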

Compound 4, half-maximal inhibitory concentration: > 5000 nM
Compound 4 ended at the assay's limit; the forecaster's own chance of this, stated with the estimate: 85%; the middle value lies beyond the limit too.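

In this assay compound 4 gives > 5000 nM, a limit of the assay and not a number. Compound 3 also stands at a limit, so the step from compound 3 to compound 4 cannot be read. The compounds shown leave open whether the methyl changes cytotoxicity at all.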